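Swapping the sulfonyl group of compound 2

The source may report more compounds than this note shows. Statements on the series, on what has been measured and on what is new or still open speak of the compounds shown alone.

Within the data shown here, in a functional assay on A549 cells (Homo sapiens) for antiproliferative activity, read by MTT assay, with a stated time of 24 h (on this read-out higher numbers stand for weaker inhibition and lower numbers for stronger inhibition), compound 2 (`Cc1ccc(C)c(S(=O)(=O)n2c(-c3cn(-c4ccccc4)nc3-c3ccc(C(F)(F)F)cc3)nc3ccccc32)c1`) gives 150 nM and holds the lower of the two numbers so far. Compound 1 (`O=[N+]([O-])c1ccc(S(=O)(=O)n2c(-c3cn(-c4ccccc4)nc3-c3ccc(F)cc3)nc3ccccc32)cc1`) gives 1030 nM in this assay and so is the weaker of the pair, by a gap beyond the scatter. The next compound to test, compound 3 (`O=[N+]([O-])c1ccc(S(=O)(=O)n2c(-c3cn(-c4ccccc4)nc3-c3ccc(C(F)(F)F)cc3)nc3ccccc32)cc1`), keeps the rest of compound 2 but has 4-nitrophenyl in place of 2,5-dimethylphenyl on a sulfonyl sulfur. The only clue to what this swap will do comes from compound 1, which also carries 4-nitrophenyl on its sulfonyl sulfur and reads 1030 nM as its value. One compound is thin evidence, but a loss of potency beyond the scatter is expected (a 2.8-fold higher number from compound 2 to compound 3 (0.45 log units; beyond the scatter)). The estimate for compound 3 is 420 nM (expected range 130 nM to 1200 nM).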

Compound 3, half-maximal inhibitory concentration: 790 nM
Beside the measured number, compound 3's estimate is 1.9-fold (0.27 log units) below it; measured number inside the range.
By their numbers in this assay, from the lowest: compound 2; then compounds 3 and 1 (each within the scatter of the next).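

In this assay, the group on the sulfonyl sulfur matters: putting 4-nitrophenyl in place of 2,5-dimethylphenyl gives a 5.3-fold higher number from compound 2 to compound 3 (0.72 log units; beyond the scatter), so the loss of potency is now seen in a pair that differs in this one place only. The second pair tests the other difference, trifluoromethyl in place of fluoro on an aromatic carbon, and gives a 1.3-fold lower number from compound 1 to compound 3 (0.12 log units; within the scatter), so with 4-nitrophenyl on the sulfonyl sulfur these two compounds cannot be told apart. Nothing in the data at hand explains either result.

On these data alone, it remains open how a phenyl ring carrying an amine or a carboxylic acid, or a plain methyl group, would read on the sulfonyl sulfur in this assay. Also open, as far as these compounds go, is whether fluoro and trifluoromethyl would still read alike with 2,5-dimethylphenyl on that sulfur.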